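A Methoxy Added to the Outer Phenyl Ring

This account rests on a few compounds, and the source may have more. Where it says the series, first, only, none or still open, it means among the compounds named here.

Of the compounds shown here, two built on one shared core have been tested in a functional assay on SK-MEL-2 cells (Homo sapiens) for inhibition; on this read-out higher numbers stand for weaker inhibition of growth and lower numbers for stronger inhibition of growth. Compound 1 `COc1cc(/C=C/C(=O)c2cccc(-n3cc(-c4ccccc4)[nH]c3=O)c2)cc(OC)c1OC` gives 2060 nM. Compound 2 `COc1cc(/C=C/C(=O)c2cccc(-n3cc(-c4ccccc4)[nH]c3=O)c2)ccc1O` gives 3650 nM in this assay, the highest of the two numbers, but its gap to compound 1 falls within the usual scatter, so the two cannot be told apart. A further compound, compound 3 `COc1ccc(-c2cn(-c3cccc(C(=O)/C=C/c4ccc(O)c(OC)c4)c3)c(=O)[nH]2)cc1`, has not yet been measured. It differs from compound 2 in one place: methoxy in place of hydrogen on an aromatic carbon. Cut one bond further out, the same difference reads phenyl to 4-methoxyphenyl. Among the compounds with values here, no measured pair shows what this change does on this core, so nothing points one way or the other. Compound 3 is therefore expected to sit close to compound 2, with a step of a 1.0-fold lower number from compound 2 to compound 3 (0.02 log units; within the scatter) that stays within the scatter. The estimate for compound 3 in this assay is 3500 nM, with a range from 1200 nM to 10000 nM.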

Compound 3, concentration for 50% growth inhibition: 5540 nM
The estimate for compound 3 lay 1.6-fold (0.20 log units) below the measured number, within the range that was stated.
By their numbers in this assay, from the lowest: compounds 1, 2 and 3 (each within the scatter of the next, the first and the last beyond it).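

Within the data shown here, this is the first measured look at phenyl to 4-methoxyphenyl on the shared core: in this assay, the change gives a 1.5-fold higher number from compound 2 to compound 3 (0.18 log units; within the scatter) and so cannot be told apart from repeat measurement. Compound 2 and compound 3 therefore count as equal on this read-out, and a methoxy para to a large group brings no clear gain or loss in growth inhibition. No measurement shown here offers an explanation for the size of this step.

As far as these compounds go, whether this position is insensitive to substitution in general remains open, since an amine or a carboxylic acid in place of the methoxy could behave differently. From the compounds shown here alone, it is also open whether the same methoxy would give a similar result on the core of compound 1.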